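This account rests on a few compounds, and the source may have more. Where it says the series, first, only, none or still open, it means among the compounds named here.

Measured so far:
Compound 1, `C#CCN(C)CCCOc1ccc2ccc(=O)oc2c1`, gives 1090 nM in an assay on isolated protein for inhibition of Amine oxidase [flavin-containing] B (Homo sapiens), read by fluorescence and Amplex Red, with stated times of 15 min and 20 min; a higher number here means a weaker inhibitor, a lower number a stronger inhibitor.
Compound 2, `C#CCN(CCCOc1ccc2ccc(=O)oc2c1)Cc1ccc(C(C)C)cc1`, gives 7580 nM in this assay.

Compound 2 carries the highest number of the two; compound 1 stands nearest, separated by a 7.0-fold higher number from compound 1 to compound 2 (0.84 log units; beyond the scatter). Compound 3, `C#CCN(CCCOc1ccc2ccc(=O)oc2c1)Cc1cccc(OC)c1`, remains unmeasured. The change is 3-methoxyphenyl in place of 4-isopropylphenyl on a saturated chain carbon bound to an amine nitrogen. For the measured compounds named here, no measured pair covers this exchange of one aryl group for another; the only step that bears on it is the move from hydrogen to an aryl group at the same place, a 7.0-fold higher number from compound 1 to compound 2 (0.84 log units; beyond the scatter). The number for compound 3 is expected to stay close to compound 2, perhaps somewhat lower, as a 1.7-fold lower number from compound 2 to compound 3 (0.23 log units; within the scatter). Compound 3 is estimated at 4500 nM, within 1500 nM to 13000 nM.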

Compound 3, half-maximal inhibitory concentration: 4590 nM
The estimate for compound 3 lay 1.0-fold (0.01 log units) below the measured number; measured number inside the range.
By their numbers in this assay, from the lowest: compound 1; then compounds 3 and 2 (each within the scatter of the next).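

In this assay, 3-methoxyphenyl in place of 4-isopropylphenyl on a saturated chain carbon bound to an amine nitrogen gives (a 1.7-fold lower number from compound 2 to compound 3 (0.22 log units; within the scatter)), so these two aryl groups are not told apart here. A second aryl group in place of hydrogen at this place also gives a step beyond the scatter (a 4.2-fold higher number from compound 1 to compound 3 (0.62 log units; beyond the scatter)), and compound 1 keeps the lowest number. No evidence on the cause of either step bears on this result.

As far as these compounds go, whether a small alkyl group such as ethyl in place of hydrogen already raises the number remains open. From the compounds shown here alone, the effect of a carboxylic acid or an amine on the aryl ring also remains open.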